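The source may report more compounds than this note shows. Statements on the series, on what has been measured and on what is new or still open speak of the compounds shown alone.

Working notes on the series. Compound 3 `C=CC(=O)Nc1cccc(-c2cn3c(C(=O)OCC)csc3n2)c1` stands only at a limit in a functional assay on MV4-11 cells (Homo sapiens) for cytotoxicity, read by MTT assay, with a stated time of 72 h; a higher number here means a weaker inhibitor, a lower number a stronger inhibitor: in this assay compound 3 gives > 20000 nM, which is a limit of the assay and not a number. Compound 1 `CCOC(=O)c1csc2nc(-c3cccc(NC(=O)c4ccco4)c3)cn12` gives > 20000 nM, again a limit. Compound 2 `CCOC(=O)c1csc2nc(-c3cccc(NC(=O)CC)c3)cn12` gives > 20000 nM, likewise a limit. Hence the steps a step that the two limits leave unreadable from compound 1 to compound 2, a step that the two limits leave unreadable from compound 1 to compound 3 and a step that the two limits leave unreadable from compound 2 to compound 3 cannot be read, and the limit of > 20000 nM in this assay, at which 3 of the 3 values shown sit, is all that the numbers show. Compound 4 `CCOC(=O)c1csc2nc(-c3cccc(NC(=O)CCl)c3)cn12` differs from compound 3 by chloromethyl in place of vinyl on a carbonyl carbon. Among the measured compounds shown here, no measured step bears on this change, and no step beyond the scatter has been resolved anywhere. Compound 4 is therefore expected around 25000 nM, with a range from 8000 nM to 80000 nM. The step that the limit leaves unreadable from compound 3 to compound 4 is thus expected to be none beyond the scatter.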

Compound 4, half-maximal inhibitory concentration: 17700 nM
Estimate against measurement, compound 4: 1.4-fold (0.15 log units) above; the range from low to high includes it.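

Among the compounds shown here, compound 4 is the only compound of the series to return a number and not a limit in this assay. Its steps are an at least 1.1-fold lower number from compound 3 to compound 4 (0.05 log units; that floor lies within the scatter), an at least 1.1-fold lower number from compound 2 to compound 4 (0.05 log units; that floor lies within the scatter) and an at least 1.1-fold lower number from compound 1 to compound 4 (0.05 log units; that floor lies within the scatter), each a floor within the scatter, so no effect of chloromethyl on the carbonyl carbon is resolved. The steps among the other compounds cannot be read, and the series stays close to its limit: the limit of > 20000 nM in this assay, at which 3 of the 4 values shown sit.

Going by these compounds, the true size of each step remains open. Also open, on these data alone, is whether an amine or a longer chain on this carbonyl carbon would give a lower number.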